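A few compounds are considered here, and "the series" means these few. Any claim that something is new, unique, unknown or untested is made for them only; others in the source may bear on it.

Compound 2 `CS(=O)(=O)c1ccc(-c2cnc(N)c(-c3ccc(N)nc3)n2)cc1` is the point of departure. In an ADME assay on microsomes from liver (Mus musculus) for metabolic stability, read by LC-MS, using NADPH, with a stated time of 30 min, tested at 0.1 uM, in the presence of a further agent that is not named here (on this read-out higher numbers stand for a more stable compound and lower numbers for a less stable compound), compound 2 gives > 90%, which is a limit of the assay and not a number. Among the compounds with values here, compound 1 `N#Cc1ccc(-c2cnc(N)c(-c3ccc(N)nc3)n2)cc1` is its only measured neighbour that differs in one place. In this assay compound 1 gives > 90%, again a limit. The step that the two limits leave unreadable from compound 1 to compound 2 therefore cannot be sized, since both values sit at the limit of > 90% in this assay, at which 2 of the 2 values shown sit. Compound 3 `Nc1ccc(-c2nc(-c3ccc(S(=O)(=O)C4CC4)cc3)cnc2N)cn1` is the next member to be measured. It differs from compound 2 by cyclopropyl in place of methyl on a sulfonyl sulfur. Within the data shown here, only the step from compound 1 to compound 2 bears on this change, and its size is not readable, so no direction beyond the scatter can be drawn from the measured steps, while both known values stand at the upper limit. For compound 3 the estimate in this assay is 90%, with a range from 76% to 98%. The expected step of a number no higher from compound 2 to compound 3 (the limit leaves the size open) is estimated as none beyond the scatter.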

Compound 3, percent of the compound remaining in the Mus musculus assay: > 90%
Compound 3: no number, only a limit; the forecaster's own chance of this, stated with the estimate: 65%; the middle value sits exactly at the limit.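

No step among compound 1, compound 2 and compound 3 can be read in the Mus musculus assay, since all three values are limits of the assay and not numbers: the limit of > 90% in the Mus musculus assay, at which 3 of the 3 values shown sit.

In a physicochemical assay for solubility, read by HPLC, using the shake flask method, in phosphate buffer, with a stated time of 2 h, at pH 6.5 (on this read-out higher numbers stand for higher solubility and lower numbers for lower solubility), compound 2 gives 149000 nM and compound 3 gives 13000 nM. That is an 11-fold lower number from compound 2 to compound 3 (1.06 log units; beyond the scatter).

The compounds shown leave open whether these three differ at all in the Mus musculus assay.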